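Chloro added to the phenyl of compound 2

The source may report more compounds than this note shows. Statements on the series, on what has been measured and on what is new or still open speak of the compounds shown alone.

Measured so far:
compound 1: `CN(C(=O)CCCc1ccccc1)c1nc2ccccc2c(=O)s1`
compound 2: `O=C(C/C=C/c1ccccc1)Nc1nc2ccccc2c(=O)s1`

For the measured compounds named here, both compounds share one core and have been measured in an assay on CHO cells for displacement of a labelled ligand from adenosine receptor A3 (Homo sapiens), read by scintillation counting, with a stated time of 60 min; on this read-out lower numbers stand for stronger inhibition and higher numbers for weaker inhibition. Compound 2 gives 158 nM. For compound 1 the result is a limit, > 1000 nM, and not a number. Going by the values given here, compound 2 therefore holds the only number among the values shown; the other entry is a limit (the limit of > 1000 nM in this assay, at which 1 of the 2 values shown sits). Among the compounds with values here, no step between measured compounds is available, so nothing measured yet tells how a change on the phenyl shifts this read-out.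

Compound 3 `O=C(C/C=C/c1cccc(Cl)c1)Nc1nc2ccccc2c(=O)s1` is not yet measured. It differs from compound 2 by chloro in place of hydrogen on an aromatic carbon. Within the data shown here, with no measured step to lean on, the estimated step from compound 2 to compound 3 is expected to be small, a 1.4-fold lower number from compound 2 to compound 3 (0.16 log units; within the scatter), within the usual scatter or at most a modest gain. On that basis compound 3 is expected to give 110 nM in this assay, with a range of 30 nM to 400 nM.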

Compound 3, inhibition constant: > 1000 nM
Compound 3: a limit, no number; the forecaster's own chance of this, stated with the estimate: 5%; middle value at least 9.0-fold (0.95 log units) away from the limit.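

Phenyl to 3-chlorophenyl gives an at least 6.3-fold higher number from compound 2 to compound 3 (0.80 log units; beyond the scatter) in this assay, the only step in the series that can be read so far. A single added chlorine atom on the aromatic carbon meta to a large group is therefore enough to move the read-out beyond the scatter, so this place on the phenyl is not indifferent to substitution. The value of compound 3 is a limit and not a number, so the full size of the step stays unknown: the limit of > 1000 nM in this assay, at which 2 of the 3 values shown sit.

The compounds shown leave open whether this loss is specific to chloro or would also follow from a fluoro, methyl or methoxy group at the same place. They also leave open whether chloro at another place on the phenyl would shift the read-out in the same way.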